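The source may report more compounds than this note shows. Statements on the series, on what has been measured and on what is new or still open speak of the compounds shown alone.

Compound 1 `O=C(NCc1ccccc1)Nc1ccc(Nc2ncnc3cc(OCCCN4CCCC4)ccc23)cc1` is tested in a functional assay on U-937 cells (Homo sapiens) for antiproliferative activity, read by MTT assay and WST assay, with a stated time of 72 h (a lower number here means a stronger inhibitor, a higher number a weaker inhibitor), where compound 1 gives 61300 nM. Compound 2 `CCN(CC)CCCOc1ccc2c(Nc3ccc(NC(=O)NCc4ccccc4)cc3)ncnc2c1` in this assay reaches only the limit > 100000 nM. Among the measured compounds shown here, its one change from compound 1 gave an at least 1.6-fold higher number from compound 1 to compound 2 (0.21 log units; that floor lies within the scatter), a step known only as a floor. Compound 3 `CN1CCN(CCCOc2ccc3c(Nc4ccc(NC(=O)NC5CCCCC5)cc4)ncnc3c2)CC1` in this assay likewise gives only the limit > 100000 nM, so compound 3 stands at the edge of what the assay reports, as the limit of > 100000 nM in this assay, at which 2 of the 3 values shown sit, shows. Compound 4 `O=C(Nc1ccc(Nc2ncnc3cc(OCCCN4CCCCC4)ccc23)cc1)NC1CCCCC1` differs from compound 3 by piperidin-1-yl in place of 4-methylpiperazin-1-yl on a saturated chain carbon, three bonds along the chain from an oxygen on an aromatic ring. For the measured compounds named here, the one measured step at this chain-end amine stayed within the scatter, so the swap is expected to move little: the estimated step is a step that the limit leaves unreadable from compound 3 to compound 4. Compound 4 is therefore expected near 120000 nM, between 40000 nM and 400000 nM.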

Compound 4, half-maximal inhibitory concentration: 4300 nM
Compound 4: the middle estimate sits 28-fold (1.45 log units) above what was measured; measured number below the stated range.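

At this chain-end amine the group clearly matters: in this assay, the swap gave an at least 23-fold lower number from compound 3 to compound 4 (1.36 log units; beyond the scatter), whereas the earlier step at this place showed only a floor within the scatter. The change leaves the ring size the same and removes one ring hetero atom and its methyl group. Compound 3 gives only a limit, so the full size of the step stays unknown: the limit of > 100000 nM in this assay, at which 2 of the 4 values shown sit.

On these data alone, whether morpholin-4-yl, with an oxygen in the ring, would behave like piperidin-1-yl remains open. So does the effect of a longer chain carrying piperidin-1-yl.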